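Swapping the aryl group on sulfur in a cinnamamide

The source may hold more compounds than are shown below. What is called first, only, known or untested is meant among the compounds shown, and "the series" means these compounds.

Measured compounds:
compound 1 `COc1ccc(SCc2ccc(/C=C/C(=O)Nc3ccccc3N)cc2)cc1OC` gives 10.1%
compound 2 `Nc1ccccc1NC(=O)c1ccc(CSc2ccc(C(F)(F)F)cn2)cc1` gives 11.5%
compound 3 `Nc1ccccc1NC(=O)c1ccc(CSc2cccc(F)c2)cc1` gives 22.5%

These three compounds were tested in a functional assay on HeLa cells (Homo sapiens) for inhibition, read by CCK-8 assay, with a stated time of 72 h, tested at 2 uM; a lower number here means less inhibition of growth, a higher number more inhibition of growth at the concentration tested. Compound 1 has the lowest of the three numbers. Its nearest neighbour is compound 2, whose value lies within the scatter of that of compound 1, so no order between these two can be drawn. Compound 3 stands furthest away, and the gap from compound 1 to compound 3 lies beyond the scatter.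

The compound not yet measured is compound 4 `Nc1ccccc1NC(=O)/C=C/c1ccc(CSc2ccc(C(F)(F)F)cn2)cc1`. It keeps the core of compound 1 and differs from it in one place: 5-(trifluoromethyl)pyridin-2-yl in place of 3,4-dimethoxyphenyl on a sulfur. The same aryl group on sulfur that enters here is also present in compound 2, which in this assay gives 11.5%, a number within the scatter of compound 1.

Within the data shown here, no pair of measured compounds differs in only this one place, so no directly measured step is available. Based on compound 1 giving 10.1% and compound 2 giving 11.5%, only a small step is expected, not beyond the scatter. The expected step from compound 1 to compound 4 is a number 2.9 percentage points higher from compound 1 to compound 4 (within the scatter). Compound 4 is therefore estimated at 13%, within a range from 3% to 25%.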

Compound 4, percent growth inhibition at one concentration: 6.07%
Compound 4: middle estimate off by 6.9 percentage points, on the high side; the range from low to high includes it.
By their numbers in this assay, from the lowest: compounds 4, 1 and 2 (each within the scatter of the next); then compound 3.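

In this assay, among these compounds, the swap of 3,4-dimethoxyphenyl for 5-(trifluoromethyl)pyridin-2-yl on the sulfur gives the first direct reading at this place, and that reading is a number 4 percentage points lower from compound 1 to compound 4 (within the scatter) for this change. The two groups differ in their ring atoms and in what they carry, one a ring of carbon only with two methoxy groups and the other a ring with one hetero atom and a trifluoromethyl group, yet compound 1 gives 10.1% and compound 4 gives 6.07% and these two numbers cannot be put in order. Nothing available here accounts for this result.

Among the compounds shown here, this single step covers only two aryl groups on the sulfur in the shared core, so it remains open whether a different kind of group at this place, such as a plain phenyl ring, a ring bearing a carboxylic acid or an amine, or a longer chain, would give a number beyond the scatter. From the compounds shown here alone, it also remains open whether compound 1 and compound 4 would separate at any other concentration.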